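Swapping the aryl group on the ring nitrogen once more

The source may hold more compounds than are shown below. What is called first, only, known or untested is meant among the compounds shown, and "the series" means these compounds.

Compound 1, `Oc1cc(C(F)(F)F)ccc1-c1nc(-c2ccccc2O)n(-c2ccc(Cl)cc2)n1`: 68%
Compound 2, `N#Cc1ccc(-n2nc(-c3ccc(C(F)(F)F)cc3O)nc2-c2ccccc2O)cc1`: 66.6%
Compound 3, `COc1cccc(-n2nc(-c3ccc(C(F)(F)F)cc3O)nc2-c2ccccc2O)c1`: 68.3%

In a functional assay on PC-12 cells (Rattus norvegicus) for cytotoxicity, read by MTT assay, with stated times of 2 h and 24 h, tested at 1 uM (on this read-out higher numbers stand for a stronger effect at the one concentration tested and lower numbers for a weaker effect), the three numbers lie close together. Compound 3 stands nominally at the top, yet both a number 0.3 percentage points higher from compound 1 to compound 3 (within the scatter) and a number 1.7 percentage points higher from compound 2 to compound 3 (within the scatter) are within the scatter, so no order among the three can be claimed. Compound 4, `Oc1cc(C(F)(F)F)ccc1-c1nc(-c2ccccc2O)n(-c2cc(F)cc(F)c2)n1`, carries the change (3,5-difluorophenyl in place of 3-methoxyphenyl on an aromatic nitrogen). Every measured step touches the same aryl group on the aromatic nitrogen: a number 1.4 percentage points lower from compound 1 to compound 2 (within the scatter), a number 0.3 percentage points higher from compound 1 to compound 3 (within the scatter) and a number 1.7 percentage points higher from compound 2 to compound 3 (within the scatter), none beyond the scatter. The step of a number 1.3 percentage points lower from compound 3 to compound 4 (within the scatter) is therefore expected to stay within the scatter as well. Compound 4 is estimated at 67%, expected between 57% and 77%.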

Compound 4, a percentage reported as activity, at one concentration (the size of the read-out at that concentration, not a potency): 75.5%
Beside the measured number, compound 4's estimate is 8.5 percentage points below it, and the stated range covers the measured number.
By their numbers in this assay, from the lowest: compounds 2, 1, 3 and 4 (each within the scatter of the next).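

In this assay, among the compounds shown here, the 3,5-difluorophenyl group on the aromatic nitrogen gives a number 7.2 percentage points higher from compound 3 to compound 4 (within the scatter) and a number 8.9 percentage points higher from compound 2 to compound 4 (within the scatter) and a number 7.5 percentage points higher from compound 1 to compound 4 (within the scatter) so these steps are larger than those among the earlier compounds, yet none leaves the scatter. The entering group counts no hydrogen-bond acceptor where 3-methoxyphenyl counts one, and this exchange also stays within the scatter. Nothing available here explains the size of these steps. On these data alone, whether an amine or a carboxylic acid on this aryl group, or an alkyl chain in its place, would give a step beyond the scatter remains open.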